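The source may report more compounds than this note shows. Statements on the series, on what has been measured and on what is new or still open speak of the compounds shown alone.

Measured in a functional assay on PC-3 cells (Homo sapiens) for inhibition, read by sulforhodamine B assay, with a stated time of 48 h, tested at 50 uM; on this read-out lower numbers stand for less inhibition of growth and higher numbers for more inhibition of growth at the one concentration tested:
Compound 1 `O=C(Nc1cn2cc(I)ccc2n1)C(F)(F)F`: 50.9%
Compound 2 `O=C(c1ccc(C(F)(F)F)c(F)c1)c1ccc2nc(NC(=O)C(F)(F)F)cn2c1`: 32.6%
Compound 3 `Cc1ccc(F)c(C(=O)c2ccc3nc(NC(=O)C(F)(F)F)cn3c2)c1`: 59.2%

Compound 3, at 59.2%, lies within the usual scatter of compound 1 and clearly above compound 2. Compound 4 `Cc1ccc(C(=O)c2ccc3nc(NC(=O)C(F)(F)F)cn3c2)cc1F` keeps the same atoms but joins them differently, with 3-fluoro-4-methylphenyl in place of 2-fluoro-5-methylphenyl on a carbonyl carbon. Within the data shown here, no measured pair isolates this kind of change. Among the measured compounds shown here, the only guide is that compound 2, with another group on the carbonyl, gives 32.6%, so such groups can matter. A modest fall is therefore expected, one that may not clear the scatter. The estimated change is a number 11.2 percentage points lower from compound 3 to compound 4 (beyond the scatter). The expected value for compound 4 is 48%, with a range of 30% to 66%.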

Compound 4, percent growth inhibition at one concentration: 30.7%
For compound 4 the middle estimate is 17.3 percentage points above the measured one; the measured number falls inside the stated range.
By their numbers in this assay, from the lowest: compounds 4 and 2 (each within the scatter of the next); then compounds 1 and 3 (each within the scatter of the next).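

Putting 3-fluoro-4-methylphenyl in place of 2-fluoro-5-methylphenyl on a carbonyl carbon gives in this assay a number 28.5 percentage points lower from compound 3 to compound 4 (beyond the scatter) even though the atoms stay the same, so how they are joined matters at this position. Methyl in place of trifluoromethyl on an aromatic carbon gives a number 1.9 percentage points lower from compound 2 to compound 4 (within the scatter) and thus shows no clear effect. Nothing measured here explains the fall in growth inhibition. From the compounds shown here alone, whether an amine or a carboxylic acid on this aromatic ring would raise or lower growth inhibition remains open.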